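From 3,5-dimethylphenyl to 2,6-dimethylphenyl

A few compounds are considered here, and "the series" means these few. Any claim that something is new, unique, unknown or untested is made for them only; others in the source may bear on it.

- compound 1 `Cc1nc(-c2ccccc2)c(C(=O)N2CCN(c3cccc(C(N)=O)c3)CC2)o1` gives 71 nM
- compound 2 `Cc1nc(-c2ccccc2)c(C(=O)N2CCN(c3ccc(F)cc3)CC2)o1` gives > 1000 nM as a limit of the assay, not a number
- compound 3 `Cc1cc(C)cc(N2CCN(C(=O)c3oc(C)nc3-c3ccccc3)CC2)c1` gives 34.5 nM

In a functional assay on HL-60 cells (Homo sapiens) for inhibition, read by MTT assay, with a stated time of 72 h (a higher number here means a weaker inhibitor, a lower number a stronger inhibitor), compound 3 holds the lowest of the two true numbers. Compound 4 `Cc1nc(-c2ccccc2)c(C(=O)N2CCN(c3c(C)cccc3C)CC2)o1` carries 2,6-dimethylphenyl in place of 3,5-dimethylphenyl on an amine nitrogen in a ring. Changes at this nitrogen range from modest, a 2.1-fold lower number from compound 1 to compound 3 (0.31 log units; beyond the scatter) here, to large, with an at least 28-fold lower number from compound 2 to compound 3 (1.46 log units; beyond the scatter) and an at least 14-fold higher number from compound 1 to compound 2 (1.14 log units; beyond the scatter) as the cases. None of these steps only relocates the methyl groups, so the size remains uncertain. Compound 3 at 34.5 nM has both other compounds on the higher side, so a moderate rise in this assay is expected. The estimated step is a 4.3-fold higher number from compound 3 to compound 4 (0.64 log units; beyond the scatter) and no more than that is assumed. For compound 4 the estimated value is 150 nM with an expected range from 40 nM to 700 nM.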

Compound 4, half-maximal inhibitory concentration: 146 nM
For compound 4 the middle estimate is 1.0-fold (0.01 log units) above the measured one; the range from low to high includes it.
By their numbers in this assay, from the lowest: compound 3; then compound 1; then compound 4. At a limit, above all of these: compound 2.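

In this assay, relocating the two methyl groups alone gives a 4.2-fold higher number from compound 3 to compound 4 (0.63 log units; beyond the scatter), so with the same atoms on the amine nitrogen, their placing on the phenyl ring changes the result. The 2,6-dimethylphenyl group also loses to 3-carbamoylphenyl, with a 2.1-fold higher number from compound 1 to compound 4 (0.31 log units; beyond the scatter), whereas 3,5-dimethylphenyl had the lower number of that pair. The remaining step, an at least 6.8-fold lower number from compound 2 to compound 4 (0.83 log units; beyond the scatter), is only a bound set by a limit of the assay: the limit of > 1000 nM in this assay, at which 1 of the 4 values shown sits.

From the compounds shown here alone, it remains open whether a single methyl group, or a pair of methoxy groups or chlorine atoms, would follow the 3,5-dimethylphenyl or the 2,6-dimethylphenyl result.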